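Imidazolidinone aryl sulfonamides: antiproliferative notes toward compound 3

The compounds below may be only part of what the source reports. "The series", "measured", "known", "first", "only" and "open" are said of these compounds alone.

Two members of the series have been measured. Compound 1 `O=C1NCCN1c1ccc(S(=O)(=O)Nc2ccc(OC(F)F)cc2)cc1` carries a 4-(difluoromethoxy)phenyl group on the sulfonamide nitrogen; in a functional assay on MCF7 cells (Homo sapiens) for antiproliferative activity, read by sulforhodamine B assay, with a stated time of 48 h (on this read-out lower numbers stand for stronger inhibition and higher numbers for weaker inhibition), compound 1 gives 760 nM. Compound 2 `Cc1cccc(NS(=O)(=O)c2ccc(N3CCNC3=O)cc2)c1C` carries a 2,3-dimethylphenyl group in the same place, and in this assay compound 2 gives 230 nM. Of the two numbers compound 2 holds the lower one, and the gap to compound 1 is larger than the scatter of repeat measurements, so compound 2 stands as the stronger inhibitor of the pair.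

The next compound, compound 3 `O=C1NCCN1c1ccc(S(=O)(=O)Nc2ccc(Cl)cc2)cc1`, differs from compound 2 in one place: 4-chlorophenyl in place of 2,3-dimethylphenyl on a sulfonamide nitrogen. Compound 2 and compound 3 were not compared directly in any measured step, so the direction of the change can only be read off the pair already in hand. With compound 1 giving 760 nM for another aryl group, the step from compound 2 to compound 3 is expected to be a modest loss, a 2.2-fold higher number from compound 2 to compound 3 (0.34 log units; beyond the scatter), possibly still inside the scatter. Compound 3 is therefore estimated at 500 nM in this assay, with a range from 200 nM to 1400 nM.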

Compound 3, half-maximal inhibitory concentration: 170 nM
Compound 3: middle estimate off by 2.9-fold (0.47 log units), on the high side; the whole stated range lies above it.
By their numbers in this assay, from the lowest: compounds 3 and 2 (each within the scatter of the next); then compound 1.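

In this assay, the swap on the sulfonamide nitrogen gives a 1.4-fold lower number from compound 2 to compound 3 (0.13 log units; within the scatter), so 4-chlorophenyl and 2,3-dimethylphenyl cannot be told apart at this position, despite their different substitution. The comparison with compound 1 adds what the earlier pair could not show, a change in one place on an aromatic carbon with chloro in place of difluoromethoxy, and this one does separate, with a 4.5-fold lower number from compound 1 to compound 3 (0.65 log units; beyond the scatter): the group on that aromatic carbon matters in this assay, and chloro is the better of these two groups there. No measurement at hand bears on why either step has the size it has.

The compounds shown leave open whether an aryl group carrying an amine or a carboxylic acid on the sulfonamide nitrogen would stay near the level of compound 3 at 170 nM, and whether a saturated group such as cyclohexyl could replace the aryl group there at all. Within the data shown here, also open is whether the flat response to the swap between 4-chlorophenyl and 2,3-dimethylphenyl holds for other aryl groups, since the series so far rests on only three compounds.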